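Swapping the amine substituent: tolerance in HEL cells

The source may report more compounds than this note shows. Statements on the series, on what has been measured and on what is new or still open speak of the compounds shown alone.

Three measured compounds share one core and differ only in the group on an amine nitrogen. Compound 1 `Cc1cn([C@@H]2O[C@H](CO[Si](C)(C)C(C)(C)C)[C@@]3(OS(=O)(=O)C=C3NCC(=O)O)[C@H]2O[Si](C)(C)C(C)(C)C)c(=O)n(C)c1=O` carries a carboxymethyl there, and in a functional assay on HEL cells (Homo sapiens) for cytotoxicity, read by microscopy (a lower number here means that less compound is tolerated, a higher number that more compound is tolerated), compound 1 gives 300000 nM. Compound 2 `CCOC(=O)CNC(=O)NC1=CS(=O)(=O)O[C@@]12[C@@H](CO[Si](C)(C)C(C)(C)C)O[C@@H](n1cc(C)c(=O)n(C)c1=O)[C@@H]2O[Si](C)(C)C(C)(C)C` carries a ((ethoxycarbonyl)methyl)carbamoyl, and in this assay compound 2 gives 16000 nM, the lower of the two numbers: a 19-fold lower number from compound 1 to compound 2 (1.27 log units; beyond the scatter). Compound 3 `Cc1cn([C@@H]2O[C@H](CO[Si](C)(C)C(C)(C)C)[C@@]3(OS(=O)(=O)C=C3NC(=O)c3ccccc3)[C@H]2O[Si](C)(C)C(C)(C)C)c(=O)n(C)c1=O` carries a benzoyl, and its result in this assay is a limit, >= 3200 nM. For the measured compounds named here, the steps ending at compound 3 cannot be sized: a step that the limit leaves unreadable from compound 1 to compound 3, and likewise a step that the limit leaves unreadable from compound 2 to compound 3; the only evidence about them is the limit of >= 3200 nM in this assay, at which 1 of the 3 values shown sits.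

Compound 4 `Cc1cn([C@@H]2O[C@H](CO[Si](C)(C)C(C)(C)C)[C@@]3(OS(=O)(=O)C=C3NCC(=O)C(N)=O)[C@H]2O[Si](C)(C)C(C)(C)C)c(=O)n(C)c1=O` is not yet measured. It differs from compound 2 at the amine nitrogen: (carbamoylcarbonyl)methyl in place of ((ethoxycarbonyl)methyl)carbamoyl on an amine nitrogen. Like compound 1, compound 4 attaches a methyl-linked group to that nitrogen rather than a carbamoyl, so the one readable step, a 19-fold lower number from compound 1 to compound 2 (1.27 log units; beyond the scatter), is the guide, and a move back toward the number of compound 1 is expected, though the group is not the same as in compound 1 and the reversal may be partial.

Compound 4 is therefore expected to give 100000 nM in this assay, with a range from 20000 nM to 300000 nM. That expected number means a 6.3-fold higher number from compound 2 to compound 4 (0.80 log units; beyond the scatter).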

Compound 4, minimum cytotoxic concentration: >= 16000 nM
Compound 4 ended at the assay's limit; the forecaster's own chance of this, stated with the estimate: 20%; the middle value is on the limit's open side.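

In this assay compound 4 gives >= 16000 nM, which is a limit of the assay and not a number. Putting (carbamoylcarbonyl)methyl in place of ((ethoxycarbonyl)methyl)carbamoyl on the amine nitrogen gives a number no lower from compound 2 to compound 4 (the limit leaves the size open), so a methyl-linked group other than carboxymethyl now stands at this nitrogen with no loss in tolerance against the carbamoyl group it replaces. The other steps that end at compound 4 cannot be read, and what bears on them is a limit: the limit of >= 16000 nM in this assay, at which 1 of the 4 values shown sits.

From the compounds shown here alone, whether compound 4 is tolerated as well as compound 1 stays open, and so does whether the methyl link or the group at its far end governs the reading at this nitrogen. The compounds shown also leave open how a plain ethyl group, a primary amine at the end of a longer chain, or the ethyl ester of the carboxymethyl group would read on the same nitrogen of the shared core in this assay.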